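A few compounds are considered here, and "the series" means these few. Any claim that something is new, unique, unknown or untested is made for them only; others in the source may bear on it.

Of the compounds shown here, three have so far been measured in a functional assay on HeLa cells (Homo sapiens) for cytotoxicity, read by sulforhodamine B assay; on this read-out lower numbers stand for stronger inhibition and higher numbers for weaker inhibition. Compound 1 `Cc1ccc2c(=O)n(C)c3c(c2c1)CCOc1ccccc1-3` gives 41600 nM, compound 2 `COc1ccc(Cn2c3c(c4ccccc4c2=O)CCOc2ccccc2-3)cc1` gives 4780 nM, and compound 3 `COCOc1ccccc1-c1cc2ccccc2c(=O)[nH]1` gives 620 nM. Compound 3 therefore stands at the lowest number of the three: compound 2 is the nearest to it, at a value that lies beyond the scatter above it, and compound 1 is the furthest, at a value that lies still further beyond the scatter. For the measured compounds named here, compounds 1 and 2 share a core that is not the core of compound 3, so none of the measured compounds differ from one another in a single place.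

Compound 4 `COCOc1ccccc1-c1cc2cc(C)ccc2c(=O)[nH]1` has not yet been measured. It differs from compound 3 in one place: methyl in place of hydrogen on an aromatic carbon. Going by the values given here, no step between measured compounds matches this change, so its effect in this assay cannot be read from the numbers at hand. A methyl in place of a hydrogen on an aromatic carbon is a small change, and the step from compound 3 to compound 4 is expected to be small, most likely within the usual scatter, with no certain direction. On that basis compound 4 is estimated at 700 nM. Its expected range runs from 250 nM to 2000 nM. The expected step is a 1.1-fold higher number from compound 3 to compound 4 (0.05 log units; within the scatter).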

Compound 4, half-maximal inhibitory concentration: 170 nM
The estimate for compound 4 lay 4.1-fold (0.61 log units) above the measured number; measured number below the stated range.
By their numbers in this assay, from the lowest: compound 4; then compound 3; then compound 2; then compound 1.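

In this assay, putting methyl in place of hydrogen produces a 3.6-fold lower number from compound 3 to compound 4 (0.56 log units; beyond the scatter), a modest step but one that lies beyond the scatter. This is the first change in a single place that can be read among these compounds, as the earlier three offered no such pair. It shows that this aromatic carbon, on the six-membered aromatic ring of carbon only that is part of the fused system of two rings, tolerates a methyl and that the added carbon moves the number downward rather than leaving it unchanged. Nothing at hand gives a measured reason for this shift.

This single step cannot say whether the lower number is particular to methyl or would also follow from a longer chain such as ethyl, from an amine or from a carboxylic acid at the same carbon. It also leaves open whether methyl would have a similar effect on the other carbons of this ring, or on the shared core of compound 1 and compound 2.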